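Shared-core ester series: paw edema inhibition notes

The source may hold more compounds than are shown below. What is called first, only, known or untested is meant among the compounds shown, and "the series" means these compounds.

Measured so far:
compound 1 `COc1ccccc1NCC(=O)Oc1ccc2c(C)cc(=O)oc2c1`: 19.4%
compound 2 `Cc1cc(=O)oc2cc(OC(=O)CNc3nc4ccccc4s3)ccc12`: 40.6%

Of the compounds shown here, two have been tested in a functional assay on the whole organism (strain Wistar albino) for inhibition, with Rattus norvegicus as the target, read by paw edema, with stated times of 30 min and 4 h, at a dose of 20 mg/kg by the oral route; on this read-out higher numbers stand for more inhibition at the one dose given (going by the name of the read-out) and lower numbers for less inhibition. Compound 1 `COc1ccccc1NCC(=O)Oc1ccc2c(C)cc(=O)oc2c1` gives 19.4%, the lower of the two numbers. Compound 2 `Cc1cc(=O)oc2cc(OC(=O)CNc3nc4ccccc4s3)ccc12` gives 40.6%, and its gap to compound 1 lies beyond the usual scatter. For the measured compounds named here, no step between measured compounds that differ in one place is available, so the weight of the group on the amine nitrogen cannot be read from the data.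

Compound 3 `Cc1cc(=O)oc2cc(OC(=O)CNN3C=NNC3)ccc12` differs from compound 1 by a group of 5 heavy atoms (2 carbon, 3 nitrogen; one five-membered non-aromatic ring with 3 hetero atoms) in place of a group of 8 heavy atoms (7 carbon, 1 oxygen; one six-membered aromatic ring of carbon only), on an amine nitrogen. Going by the values given here, with no matched step to lean on, the expected step from compound 1 to compound 3 in this assay is a number 5.6 percentage points higher from compound 1 to compound 3 (within the scatter), estimated as small and within the scatter, leaning upward only because compound 2 gives 40.6% with a different substituent on the same core. Compound 3 is therefore estimated at 25%, with a range from 10% to 42%.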

Compound 3, a percentage reported as inhibition, in the whole organism at one dose (the size of the read-out at that dose, not a potency): 22.2%
For compound 3 the middle estimate is 2.8 percentage points above the measured one, within the range that was stated.
By their numbers in this assay, from the lowest: compounds 1 and 3 (each within the scatter of the next); then compound 2.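

In this assay, for the compounds shown here, the change on the amine nitrogen from 2-methoxyphenyl to the five-membered non-aromatic ring with 3 hetero atoms gives a number 2.8 percentage points higher from compound 1 to compound 3 (within the scatter) and is the only step read so far at this position. At this one dose, the six-membered aromatic ring of carbon only is therefore not required on this nitrogen to keep the reading of compound 1, and the two groups cannot be told apart despite their different ring sizes and counts of donors and acceptors. Nothing on hand speaks to the reason for this.

Still open, from the compounds shown here alone, is what a methyl group or a longer chain such as n-butyl on the amine nitrogen would give, and whether an unsubstituted phenyl would read like 2-methoxyphenyl. Also open is how these readings move with dose, with one dose shown for each compound.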